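Dropping one chloro from a dichloro aniline

This account rests on a few compounds, and the source may have more. Where it says the series, first, only, none or still open, it means among the compounds named here.

The study concerns a shared core carrying a bridged diamine and an aniline-type substituent, read in an assay on cell membranes for displacement of a labelled ligand from Neuronal acetylcholine receptor; alpha4/beta2 (Rattus norvegicus); on this read-out lower numbers stand for stronger inhibition and higher numbers for weaker inhibition. Compound 1, `Clc1ccc(Nc2ccc(N3CC4CC(C3)N4)nn2)cc1Cl`, gives 516 nM in this assay, the highest of the three numbers measured. Compound 2, `COc1ccc(Nc2cncc(N3CC4CC(C3)N4)c2)cc1`, gives 0.0598 nM in this assay, and compound 3, `O=[N+]([O-])c1ccc(Nc2ccc(N3CC4CC(C3)N4)cn2)cc1`, gives 1.76 nM in this assay; both sit well below compound 1, but each also differs from it in more than one place, so their gap to compound 1 cannot be read as the effect of any single change.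

Compound 4, `Clc1ccc(Nc2ccc(N3CC4CC(C3)N4)nn2)cc1`, is not yet measured. Relative to compound 1 the difference is hydrogen in place of chloro on an aromatic carbon, the carbon that stands ortho to a chloro group and meta to a large group. Within the data shown here, no pair of measured compounds separated by only this change is available, so the size of the step rests on judgement. The account expects the step from compound 1 to compound 4 to be small, a 1.3-fold higher number from compound 1 to compound 4 (0.10 log units; within the scatter), most likely not beyond the scatter, with a slight lean toward a higher number. On that basis compound 4 is estimated at 650 nM in this assay, within a range of 200 nM to 2100 nM.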

Compound 4, inhibition constant: 90.4 nM
Estimate against measurement, compound 4: 7.2-fold (0.86 log units) above; the whole stated range lies above it.
By their numbers in this assay, from the lowest: compound 2; then compound 3; then compound 4; then compound 1.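

In this assay, the chloro on the six-membered aromatic ring of carbon only, on the carbon ortho to a chloro group and meta to a large group, turns out not to be neutral: replacing it with hydrogen gives a 5.7-fold lower number from compound 1 to compound 4 (0.76 log units; beyond the scatter), a step beyond the scatter. Among these compounds, this is the first change in the set that can be read on its own, since the earlier compounds differed from one another in more than one place, and it shows that, on this core, the number falls when this chloro is lost, while the other chloro stays in place. Nothing shown bears on the reason for this step.

The compounds shown leave open whether the lower number belongs to hydrogen in particular or would also appear with another small group on this carbon, such as fluoro or methyl. They also leave open what happens when the remaining chloro is replaced by hydrogen, and whether the step seen here would keep its direction and size on the differing cores of compound 2 and compound 3.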